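Phenyl in Place of Thiazolylmethoxy: Expected Cytotoxicity

The source may hold more compounds than are shown below. What is called first, only, known or untested is meant among the compounds shown, and "the series" means these compounds.

Compound 2 `COC(=O)N[C@H](C(=O)NN(CCC[C@@](O)(Cc1ccccc1)C(=O)N[C@H]1c2ccccc2C[C@H]1O)Cc1ccc(OCc2cnc(Cl)s2)cc1)C(C)(C)C` carries a (2-chloro-1,3-thiazol-5-yl)methoxy group on an aromatic carbon. In an ADME assay on MT4 cells (Homo sapiens) for cytotoxicity (on this read-out lower numbers stand for higher toxicity in this test and higher numbers for lower toxicity in this test), compound 2 gives > 10000 nM, which is a limit of the assay and not a number. Compound 1 `COC(=O)N[C@H](C(=O)NN(CCC[C@@](O)(Cc1ccccc1)C(=O)N[C@H]1c2ccccc2C[C@H]1O)Cc1ccc(-c2cncnc2)cc1)C(C)(C)C` bears pyrimidin-5-yl on that aromatic carbon instead. In this assay compound 1 gives > 10000 nM, again a limit. Going by the values given here, the only measured step, a step that the two limits leave unreadable from compound 1 to compound 2, is therefore unreadable in size, since both values rest at the limit of > 10000 nM in this assay, at which 2 of the 2 values shown sit. Compound 3 `COC(=O)N[C@H](C(=O)NN(CCC[C@@](O)(Cc1ccccc1)C(=O)N[C@H]1c2ccccc2C[C@H]1O)Cc1ccc(-c2ccccc2)cc1)C(C)(C)C` differs from compound 2 by phenyl in place of (2-chloro-1,3-thiazol-5-yl)methoxy on an aromatic carbon. Among the compounds with values here, no measured step at this position can be read, so nothing beyond the scatter is expected, and compound 3 is expected to remain at the limit as well. The estimate for compound 3 is 15000 nM, with a range from 6000 nM to 40000 nM. The expected step is a step that the limit leaves unreadable from compound 2 to compound 3.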

Compound 3, half-maximal cytotoxic concentration: 7500 nM
The estimate for compound 3 lay 2.0-fold (0.30 log units) above the measured number, and the stated range covers the measured number.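

Going by these compounds alone, with phenyl on this aromatic carbon, compound 3 gives 7500 nM in this assay, the only value shown that is a number and not a limit. Replacing the (2-chloro-1,3-thiazol-5-yl)methoxy group gives an at least 1.3-fold lower number from compound 2 to compound 3 (0.12 log units; that floor lies within the scatter), and replacing pyrimidin-5-yl gives an at least 1.3-fold lower number from compound 1 to compound 3 (0.12 log units; that floor lies within the scatter). Each step is only a floor, so the position now yields a measured number with phenyl, yet neither step is shown to exceed the scatter, and the other two values remain limits: the limit of > 10000 nM in this assay, at which 2 of the 3 values shown sit.

As far as these compounds go, the true size of both steps stays open, so it remains unsettled whether phenyl differs at all from the other two groups. Also open, from the compounds shown here alone, is what an amine or a carboxylic acid on this aromatic carbon would give in this assay.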